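The compounds below may be only part of what the source reports. "The series", "measured", "known", "first", "only" and "open" are said of these compounds alone.

Measured so far in a functional assay on 786-0 cells (Homo sapiens) for inhibition, read by sulforhodamine B assay, with a stated time of 48 h; a higher number here means a weaker inhibitor of growth, a lower number a stronger inhibitor of growth:
- compound 1 `CCOC(=O)c1nn(-c2ccccc2)c(-c2ccc(F)cc2)c1CNC(C)(C)C`: > 632000 nM; 319000 nM (2 entries)
- compound 2 `CC(C)(C)NCc1c(C(=O)O)nn(-c2ccccc2)c1-c1ccc(F)cc1`: > 680000 nM

One of the two entries for compound 1 is a limit of the assay. Compound 2 has no single number: its > 680000 nM is a limit of the assay.

Compound 3 `COc1ccc(-c2c(CNC(C)(C)C)c(C(=O)O)nn2-c2ccccc2)cc1` follows from compound 2 by one change, (methoxy in place of fluoro on an aromatic carbon), with methoxy in place of fluoro on an aromatic carbon. For the measured compounds named here, no measured step shows what such a change does. The expected step in this assay is an at least 1.3-fold lower number from compound 2 to compound 3 (0.13 log units; that floor lies within the scatter), which is none beyond the scatter. Growth inhibition is expected to stay weak, as for compound 1 at > 632000 nM; 319000 nM (2 entries). Compound 3 is estimated at 500000 nM, with an expected range from 200000 nM to 700000 nM.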

Compound 3, concentration for 50% growth inhibition: > 659000 nM
Compound 3: no number, only a limit; the forecaster's own chance of this, stated with the estimate: 65%; middle value at least 1.3-fold (0.11 log units) away from the limit.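

Compound 2 and compound 3 each carry only a limit of the assay in this assay, and no step can be read between them. On these data alone, whether 4-fluorophenyl to 4-methoxyphenyl shifts growth inhibition at all stays open.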